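A few compounds are considered here, and "the series" means these few. Any claim that something is new, unique, unknown or untested is made for them only; others in the source may bear on it.

Measured in a functional assay on A549 cells (Homo sapiens) for inhibition, read by MTT assay, with a stated time of 48 h; on this read-out higher numbers stand for weaker inhibition and lower numbers for stronger inhibition:
Compound 1 `N#Cc1ccc2[nH]cc(C(c3ccc(Br)cc3)c3c[nH]c4ccc(C#N)cc34)c2c1`: > 100000 nM, a limit of the assay and not a number
Compound 2 `OC[C@H]1O[C@@H](n2cc(C(c3ccc(Cl)cc3)c3cn([C@@H]4O[C@H](CO)[C@@H](O)[C@H](O)[C@H]4O)c4ccc(Br)cc34)c3cc(Br)ccc32)[C@H](O)[C@@H](O)[C@@H]1O`: 2700 nM
Compound 3 `OC[C@H]1O[C@@H](n2cc(C(c3ccc(Br)cc3)c3cn([C@@H]4O[C@H](CO)[C@@H](O)[C@H](O)[C@H]4O)c4ccc(Br)cc34)c3cc(Br)ccc32)[C@H](O)[C@@H](O)[C@@H]1O`: 2500 nM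

Compound 3 gives 2500 nM, and this number lies within the scatter of the number from compound 2, which is 2700 nM. For the measured compounds named here, these are the only two numbers available. Going by the values given here, compound 1 stands only at a limit, (the limit of > 100000 nM in this assay, at which 1 of the 3 values shown sits), and offers no step to work from.

Compound 4 `O=[N+]([O-])c1ccc(C(c2cn([C@@H]3O[C@H](CO)[C@@H](O)[C@H](O)[C@H]3O)c3ccc(Br)cc23)c2cn([C@@H]3O[C@H](CO)[C@@H](O)[C@H](O)[C@H]3O)c3ccc(Br)cc23)cc1` has not yet been measured. Its structure departs from that of compound 3 by nitro in place of bromo on an aromatic carbon, para to a large group, the change from 4-bromophenyl to 4-nitrophenyl: nitro in place of bromo on an aromatic carbon.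

Among the compounds with values here, one measured step bears on this change. It is a 1.1-fold lower number from compound 2 to compound 3 (0.03 log units; within the scatter), with bromo in place of chloro on an aromatic carbon, and it stays within the scatter. Within the data shown here, that step exchanges one halogen for another, and no measured compound here carries a nitro group, so it is only a weak guide. On that evidence, no shift beyond the scatter is expected in this assay, though the uncertainty is wide. The expected step is a 1.2-fold higher number from compound 3 to compound 4 (0.08 log units; within the scatter). Compound 4 is estimated at 3000 nM, with an expected range of 1000 nM to 10000 nM.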

Compound 4, half-maximal inhibitory concentration: 2400 nM
Compound 4: middle estimate off by 1.3-fold (0.10 log units), on the high side; measured number inside the range.
By their numbers in this assay, from the lowest: compounds 4, 3 and 2 (each within the scatter of the next). At a limit, above all of these: compound 1.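

With nitro in place of bromo, this position now carries a group of a different kind, not just one halogen exchanged for another: it has more heavy atoms and hydrogen-bond acceptors that bromo lacks. Even so, this assay gives a 1.0-fold lower number from compound 3 to compound 4 (0.02 log units; within the scatter). The exchange of nitro for chloro reads the same way, with a 1.1-fold lower number from compound 2 to compound 4 (0.05 log units; within the scatter), so chloro, bromo and nitro on this position of the shared core cannot be told apart on this read-out, and the position has so far tolerated a change larger than the halogen exchange alone could show. Nothing measured here speaks to why these three groups give numbers so close together.

Still open, going by these compounds, is whether this tolerance extends to groups of other kinds at the same position, such as an amine, a carboxylic acid or a longer chain, or whether one of these would move the number beyond the scatter. Also open, on these data alone, is whether nitro in place of bromo would read the same way on a core that differs elsewhere, or in cells other than the one line tested here.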